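The source may report more compounds than this note shows. Statements on the series, on what has been measured and on what is new or still open speak of the compounds shown alone.

Compound 3 `COc1cccc(N(C)c2ccc(NC(=O)C3CC3)cc2)c1` gives 12 nM in an assay on isolated protein for binding affinity to melatonin receptor type 1A (Homo sapiens) (on this read-out higher numbers stand for weaker inhibition and lower numbers for stronger inhibition), the second highest of the three numbers. Compound 1 `COc1cccc(N(C)c2ccc(NC(C)=O)cc2)c1` gives 0.05 nM, and compound 2 `COc1cccc(N(C)c2ccc(NC(=O)C(C)C)cc2)c1` gives 106 nM. Compound 4 `CCOC(=O)Nc1ccc(N(C)c2cccc(OC)c2)cc1` differs from compound 3 by ethoxy in place of cyclopropyl on a carbonyl carbon. Earlier changes at this carbonyl carbon moved this assay strongly: a 240-fold higher number from compound 1 to compound 3 (2.38 log units; beyond the scatter) and a 2100-fold higher number from compound 1 to compound 2 (3.33 log units; beyond the scatter), while an 8.8-fold lower number from compound 2 to compound 3 (0.95 log units; beyond the scatter). Every change here has therefore been beyond the scatter, though the new group differs from all three earlier ones, so the direction is uncertain. For compound 4 a modest weakening is expected, a 2.5-fold higher number from compound 3 to compound 4 (0.40 log units; beyond the scatter), with a wide range; the estimate for compound 4 is 30 nM, between 3 nM and 300 nM.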

Compound 4, inhibition constant: 34 nM
Beside the measured number, compound 4's estimate is 1.1-fold (0.05 log units) below it; the range from low to high includes it.
By their numbers in this assay, from the lowest: compound 1; then compound 3; then compound 4; then compound 2.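

In this assay, among the compounds shown here, ethoxy, the first group here joined to the carbonyl carbon through oxygen, falls among the larger replacements and does not recover the potency of compound 1, with a 680-fold higher number from compound 1 to compound 4 (2.83 log units; beyond the scatter). Its place is intermediate: a 2.8-fold higher number from compound 3 to compound 4 (0.45 log units; beyond the scatter), yet a 3.1-fold lower number from compound 2 to compound 4 (0.49 log units; beyond the scatter). Nothing available explains this order. All three replacements of methyl remain far from compound 1, so the steep loss at this carbonyl carbon is not confined to carbon-linked groups. On these data alone, whether methoxy, ethyl or an amine would stay closer to methyl remains open.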